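Series notes: five-membered ring swap on the saturated carbon

This account rests on a few compounds, and the source may have more. Where it says the series, first, only, none or still open, it means among the compounds named here.

Measured compounds:
- compound 1 `CS(=O)(=O)Nc1ccc(F)c2c1CCCC2c1c[nH]cn1`: < 10000 nM in an assay on isolated protein (Cricetulus griseus) for binding affinity to Alpha-1B adrenergic receptor (Mesocricetus auratus), read by radioligand binding (on this read-out higher numbers stand for weaker inhibition and lower numbers for stronger inhibition), a limit rather than a number.
- compound 2 `Cn1cnc(C2CCCc3c(NS(C)(=O)=O)cccc32)c1`: 2040 nM in this assay.

Among the compounds with values here, compound 2 carries the only real number in this assay; the other entry, for compound 1, is a limit of the assay (the limit of < 10000 nM in this assay, at which 1 of the 2 values shown sits). Compound 2 therefore stands alone as the reference point, with nothing to rank it against.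

Compound 3 `CS(=O)(=O)Nc1cccc2c1CCCC2C1=NCCN1` is the next compound to be measured in this assay. It differs from compound 2 by a group of 5 heavy atoms (3 carbon, 2 nitrogen; one five-membered non-aromatic ring with 2 hetero atoms) in place of a group of 6 heavy atoms (4 carbon, 2 nitrogen; one five-membered aromatic ring with 2 hetero atoms), on a saturated ring carbon. Within the data shown here, no measured step of this kind exists, so the expectation rests on compound 2 alone. A step beyond the scatter toward stronger binding is expected, of the size a 4.1-fold lower number from compound 2 to compound 3 (0.61 log units; beyond the scatter). Compound 3 is accordingly estimated at 500 nM, with a range from 100 nM to 3000 nM.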

Compound 3, inhibition constant: 7410 nM
Compound 3: middle estimate off by 15-fold (1.17 log units), on the low side; the whole stated range lies below it.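

In this assay, the saturated ring carbon now has its first readable step: putting the non-aromatic five-membered ring in place of 1-methyl-1H-imidazol-4-yl gives a 3.6-fold higher number from compound 2 to compound 3 (0.56 log units; beyond the scatter), so binding at this place depends on which ring is attached. The change alters aromaticity, removes the methyl group and brings in a hydrogen-bond donor, and a single step cannot separate these differences. Compound 1 supplies no second number for comparison, as its entry is a limit: the limit of < 10000 nM in this assay, at which 1 of the 3 values shown sits.

As far as these compounds go, it remains open whether an unsubstituted 1H-imidazol-4-yl on the core of compound 2 would behave like either ring. Also open, from the compounds shown here alone, is how a group of another kind on the saturated ring carbon, such as an aminomethyl group or a carboxylic acid, would read in this assay.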